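Chloro in Place of Methoxy: What Is Expected

The source may hold more compounds than are shown below. What is called first, only, known or untested is meant among the compounds shown, and "the series" means these compounds.

Going by the values given here, compound 2 `COc1ccc(-c2n[nH]cc2N2CCNCC2)cc1` is the one member of this pair with a number: in an assay on isolated protein for binding affinity to 5-hydroxytryptamine receptor 6 (Homo sapiens) (on this read-out higher numbers stand for weaker inhibition and lower numbers for stronger inhibition), compound 2 gives 279 nM. Compound 1 `COc1ccc(-c2n[nH]cc2N2CCCNCC2)cc1` gives a limit rather than a number, > 10000 nM, in this assay, which is the limit of > 10000 nM in this assay, at which 1 of the 2 values shown sits. Compound 3 `Clc1ccc(-c2n[nH]cc2N2CCNCC2)cc1` differs from compound 2 by chloro in place of methoxy on an aromatic carbon. Among the compounds with values here, no measured step matches this change, so the expectation rests on compound 2 alone, and a step of a 1.1-fold higher number from compound 2 to compound 3 (0.03 log units; within the scatter), no larger than the usual scatter, is expected in either direction. Compound 3 is expected to give 300 nM, between 80 nM and 1200 nM.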

Compound 3, inhibition constant: 75 nM
The estimate for compound 3 lay 4.0-fold (0.60 log units) above the measured number; the whole stated range lies above it.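

In this assay, chloro in place of methoxy on an aromatic carbon, para to a large group, gives a 3.7-fold lower number from compound 2 to compound 3 (0.57 log units; beyond the scatter). The earlier compounds shown here both carried methoxy here, so only now is it visible that the number at this position moves with the group it carries, and that the hydrogen-bond acceptor of methoxy is not needed for a number this low. Nothing measured here accounts for the step.

The compounds shown leave open whether fluoro, methyl or trifluoromethyl at this position would follow chloro. As far as these compounds go, whether the same change would hold on the core of compound 1 also stays open.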